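The compounds below may be only part of what the source reports. "The series", "measured", "known", "first", "only" and "open" are said of these compounds alone.

Compound 1 `Cc1ccc(S(=O)(=O)N/C(=N\O)Nc2ccc(Cl)cc2)cc1` gives the strongest inhibition of the three measured compounds: in a functional assay on MOLT-4 cells (Homo sapiens) for cytotoxicity (on this read-out higher numbers stand for weaker inhibition and lower numbers for stronger inhibition), compound 1 gives 6 ug/mL. Compound 2 `O=[N+]([O-])c1ccc(Oc2c(Cl)cc(S(=O)(=O)N/C(=N\O)Nc3ccc(Cl)cc3)cc2Cl)cc1` is built on a different core, and the difference between the two cores is not broken down here. In this assay compound 2 gives 55 ug/mL. Compound 3 `O=[N+]([O-])c1ccc(Oc2c(Cl)cc(S(=O)(=O)N/C(=N\O)Nc3ccc(Cl)cc3)cc2Cl)c(Cl)c1` differs from compound 2 by chloro in place of hydrogen on an aromatic carbon. In this assay compound 3 gives 56 ug/mL, so that a 1.0-fold higher number from compound 2 to compound 3 (0.01 log units; within the scatter).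

Compound 4 `Cc1ccc(S(=O)(=O)N/C(=N\O)Nc2ccc(Cl)c(Cl)c2)cc1` has not yet been measured. It differs from compound 1 by chloro in place of hydrogen on an aromatic carbon. Going by the values given here, this is the same kind of change as the one between compound 2 and compound 3, though not the same: in compound 4 the entering chloro sits ortho to a chloro group and meta to a large group, whereas in compound 3 it sits ortho to a large group and meta to a nitro group. Because a 1.0-fold higher number from compound 2 to compound 3 (0.01 log units; within the scatter), compound 4 is expected to move by only a 1.2-fold lower number from compound 1 to compound 4 (0.08 log units; within the scatter). Compound 4 is therefore estimated at 5 ug/mL, likely between 2 ug/mL and 12 ug/mL.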

Compound 4, half-maximal inhibitory concentration: 7 ug/mL
For compound 4 the middle estimate is 1.4-fold (0.15 log units) below the measured one; the range from low to high includes it.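

In this assay, adding the chloro to the core of compound 1 gives a step that stays within the scatter: a 1.2-fold higher number from compound 1 to compound 4 (0.07 log units; within the scatter). Set beside the earlier step, the same change has a similarly small size on both cores, and the two steps do not differ beyond the scatter: the same change on two cores in this assay, a 1.0-fold higher number (0.01 log units; within the scatter) from compound 2 to compound 3 and a 1.2-fold higher number (0.07 log units; within the scatter) from compound 1 to compound 4, 1.1-fold (0.06 log units) apart, within the scatter of two such steps. Going by these compounds alone, this shows that, in these two pairs, the change carried over from one core to the other without a measurable shift, but it does not show a general rule, since it rests on only two pairs, with the entering chloro in different surroundings in each, and in one assay.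

The compounds shown leave open whether a group other than chloro at this place on the ring, such as a fluoro, a methoxy, an amine or a carboxylic acid, would also leave the number unmoved. They also leave open what a longer chain in place of the methyl group of compound 1 would do.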